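Cyano in place of 1,2-oxazol-4-yl on the shared core

A few compounds are considered here, and "the series" means these few. Any claim that something is new, unique, unknown or untested is made for them only; others in the source may bear on it.

Measured in an in vitro ADME assay on microsomes from liver (Homo sapiens) for metabolic stability, tested at 5 uM; a higher number here means that the compound lasts longer, a lower number that the compound disappears faster:
- compound 1 `CC(C)CCn1nc(-c2cccs2)c(O)c(C2=NS(=O)(=O)c3cc(O)ccc3N2)c1=O` with 0.0933 h
- compound 2 `CC(C)CCn1nc(-c2cccs2)c(O)c(C2=NS(=O)(=O)c3cc(NC(=O)C4CC4)ccc3N2)c1=O` with 0.0833 h
- compound 3 `CC(C)CCn1nc(-c2cccs2)c(O)c(C2=NS(=O)(=O)c3cc(-c4cnoc4)ccc3N2)c1=O` with 0.5 h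

Compound 3 stands highest of the three, and its number lies beyond the scatter from both others. Compound 4 `CC(C)CCn1nc(-c2cccs2)c(O)c(C2=NS(=O)(=O)c3cc(C#N)ccc3N2)c1=O` differs from it in one place cyano in place of 1,2-oxazol-4-yl on an aromatic carbon with cyano in place of 1,2-oxazol-4-yl on an aromatic carbon. For the measured compounds named here, three measured steps concern this same place. The first, a 5.4-fold higher number from compound 1 to compound 3 (0.73 log units; beyond the scatter) and the second, a 6.0-fold higher number from compound 2 to compound 3 (0.78 log units; beyond the scatter) are both modest, and both end at compound 3. The third, a 1.1-fold lower number from compound 1 to compound 2 (0.05 log units; within the scatter) shows hydroxy and (cyclopropylcarbonyl)amino giving much the same result. None of these steps involves cyano, so the data do not show whether it will track 1,2-oxazol-4-yl or the two lower compounds. A small fall in this assay is therefore expected, most likely not beyond the scatter. The estimated step is a 1.4-fold lower number from compound 3 to compound 4 (0.15 log units; within the scatter) and the range around it is wide. For compound 4 the expected half-life is 0.35 h with an estimated range from 0.12 h to 1 h in this measurement.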

Compound 4, half-life: 0.16 h
Beside the measured number, compound 4's estimate is 2.2-fold (0.34 log units) above it; the measured number falls inside the stated range.
By their numbers in this assay, from the lowest: compounds 2, 1 and 4 (each within the scatter of the next); then compound 3.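

In this assay, cyano does not hold the number reached with 1,2-oxazol-4-yl at this aromatic carbon, the exchange giving a 3.1-fold lower number from compound 3 to compound 4 (0.49 log units; beyond the scatter). Set against the two lower compounds, cyano gives a 1.9-fold higher number from compound 2 to compound 4 (0.28 log units; within the scatter) and a 1.7-fold higher number from compound 1 to compound 4 (0.23 log units; within the scatter), so compound 4 groups with them and, of the four groups compared here, only 1,2-oxazol-4-yl stands apart. No measurement available here accounts for this difference.

The compounds shown leave open whether the higher number belongs to 1,2-oxazol-4-yl alone or extends to other five-membered aromatic rings, such as a pyrazolyl or thiazolyl ring. They also leave open how an amine or a carboxylic acid at this place would compare.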